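The source may report more compounds than this note shows. Statements on the series, on what has been measured and on what is new or still open speak of the compounds shown alone.

Measured so far, in a functional assay on U-251 cells (Homo sapiens) for cytotoxicity, read by sulforhodamine B assay, with a stated time of 48 h, tested at 50 uM; on this read-out higher numbers stand for more inhibition at the one concentration tested (going by the name of the read-out) and lower numbers for less inhibition:
- compound 1 `FC(F)(F)c1ccc(Nc2nccc(-c3cnc4ccccc4c3)n2)cc1` gives 49.8%
- compound 2 `Nc1nccc(-c2cnc3ccccc3c2)n1` gives 38.5%

Compound 2 stands lowest of the two numbers measured in this assay; its nearest neighbour is compound 1, whose number lies higher by a gap beyond the usual scatter. The two share the same core and differ only in what sits on the nitrogen on the aromatic ring: compound 1 carries a 4-(trifluoromethyl)phenyl group there, compound 2 a hydrogen.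

Compound 3 `Cc1ccc(Nc2nccc(-c3cnc4ccccc4c3)n2)cc1` has not yet been measured in this assay. It differs from compound 2 by 4-methylphenyl in place of hydrogen on a nitrogen on an aromatic ring. Within the data shown here, no single-point step between measured compounds is available to set the size of this change. Given that compound 1, which also carries an aryl group on that nitrogen, gives 49.8%, a rise of moderate size is expected, so the step of a number 8.5 percentage points higher from compound 2 to compound 3 (within the scatter) is estimated as upward. Compound 3 is expected to give about 47%, within a range from 33% to 61%.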

Compound 3, a percentage reported as inhibition, at one concentration (the size of the read-out at that concentration, not a potency): 87.7%
Estimate against measurement, compound 3: 40.7 percentage points below; measured number outside the range, above it.
By their numbers in this assay, from the lowest: compound 2; then compound 1; then compound 3.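

In this assay, 4-methylphenyl in place of hydrogen on the nitrogen gives a number 49.2 percentage points higher from compound 2 to compound 3 (beyond the scatter), so an aryl group at this place can raise the inhibition far more than the earlier pair showed. What the aryl ring carries matters greatly: methyl in place of trifluoromethyl on an aromatic carbon gives a number 37.9 percentage points higher from compound 1 to compound 3 (beyond the scatter), so the aryl ring alone does not set the size of the rise. Nothing at hand says why these two groups differ so much.

The compounds shown do not tell how a plain phenyl, or a methoxy group or carboxylic acid in place of the methyl, would read. They also leave open whether a longer chain such as ethyl would keep the inhibition this high, and a single concentration gives no potency.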